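The source may report more compounds than this note shows. Statements on the series, on what has been measured and on what is new or still open speak of the compounds shown alone.

Measured so far in an ADME assay on MCF-10A cells (Homo sapiens) for cytotoxicity, read by CCK-8 assay and cell counting, with a stated time of 72 h; on this read-out lower numbers stand for stronger inhibition and higher numbers for weaker inhibition:

- compound 1 `COc1ccc(-c2cc3ccccc3c(-c3cccc(O)c3)n2)cc1`: 7830 nM
- compound 2 `COc1ccc(-c2cc3ccccc3c(-c3cccc(OC)c3)n2)cc1`: > 50000 nM (a limit)
- compound 3 `COc1ccc(-c2cc3ccccc3c(-c3cccc(N)c3)n2)cc1`: 18800 nM

Compound 3 stands highest of the two numbers shown; its nearest neighbour is compound 1, and the gap is a 2.4-fold higher number from compound 1 to compound 3 (0.38 log units; beyond the scatter). Compound 2 gives only a limit in this assay, (the limit of > 50000 nM in this assay, at which 1 of the 3 values shown sits), so no number is known for it.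

Compound 4 `COc1ccc(-c2cc3ccccc3c(-c3ccc(O)cc3)n2)cc1` differs from compound 3 by 4-hydroxyphenyl in place of 3-aminophenyl on an aromatic carbon. Within the data shown here, two measured steps bear on it. The swap of amino back to hydroxy is covered by the reverse of a 2.4-fold higher number from compound 1 to compound 3 (0.38 log units; beyond the scatter), a modest change that points to a lower number. The change from compound 2 to compound 3, an at least 2.6-fold lower number from compound 2 to compound 3 (0.42 log units; beyond the scatter), shows that methoxy gives a higher number than amino, which is beyond the scatter. Among the measured compounds shown here, no measured step covers moving the hydroxy to the 4-position of the phenyl, so that part of the change is unknown. On this basis a modest lowering is expected, a 2.1-fold lower number from compound 3 to compound 4 (0.32 log units; beyond the scatter). Compound 4 is therefore estimated at 9000 nM, with a range from 3000 nM to 30000 nM.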

Compound 4, half-maximal inhibitory concentration: > 50000 nM
Compound 4 gave a limit, no number (the forecaster's own chance of this, stated with the estimate: 10%); middle value at least 5.5-fold (0.74 log units) from the limit.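

In this assay, among these compounds, the place of the hydroxy on this phenyl counts, which no earlier step covered: 4-hydroxyphenyl in place of 3-hydroxyphenyl gives an at least 6.3-fold higher number from compound 1 to compound 4 (0.80 log units; beyond the scatter). 4-hydroxyphenyl in place of 3-aminophenyl gives an at least 2.6-fold higher number from compound 3 to compound 4 (0.42 log units; beyond the scatter), so a hydroxy on this phenyl does not by itself keep a measurable number. Compound 4 gives a limit and not a number, as does compound 2, and the step between them cannot be read: the limit of > 50000 nM in this assay, at which 2 of the 4 values shown sit.

Going by these compounds, how far compound 4 lies past that limit remains open, so the full size of the effect of moving the hydroxy is not known. Also open, on these data alone, is whether an amino group moved in the same way, or a carboxylic acid or an amide on this phenyl, would follow compound 4 or compound 1.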